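Removing one methyl from compound 3

A few compounds are considered here, and "the series" means these few. Any claim that something is new, unique, unknown or untested is made for them only; others in the source may bear on it.

Measured in a functional assay on LS174T cells (Homo sapiens) for antiproliferative activity; a higher number here means a weaker inhibitor, a lower number a stronger inhibitor:
- compound 1 `CN(C)c1ccc(/C=C/c2c(F)cccc2Cl)cn1`: 4.7 nM
- compound 2 `CNc1ccc(/C=C/c2c(F)cccc2Cl)cn1`: 4 nM
- compound 3 `CN(C)c1ccc(/C=C/c2c(Cl)cccc2Cl)cn1`: 30.1 nM

Compound 3 has the highest number of the three, which makes it the weakest inhibitor here. Compound 4 `CNc1ccc(/C=C/c2c(Cl)cccc2Cl)cn1`, not yet measured, carries hydrogen in place of methyl on a nitrogen on an aromatic ring. The same change has been measured once, on the fluoro partner: a 1.2-fold lower number from compound 1 to compound 2 (0.07 log units; within the scatter). The other known step, a 6.4-fold higher number from compound 1 to compound 3 (0.81 log units; beyond the scatter), swaps fluoro for chloro. That is a different change from this one. No shift beyond the scatter is therefore expected in this assay. The expected step is a 1.2-fold lower number from compound 3 to compound 4 (0.06 log units; within the scatter). The estimate for compound 4 is 26 nM, with an expected range from 11 nM to 60 nM.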

Compound 4, half-maximal inhibitory concentration: 19.6 nM
Estimate against measurement, compound 4: 1.3-fold (0.12 log units) above; the range from low to high includes it.
By their numbers in this assay, from the lowest: compounds 2 and 1 (each within the scatter of the next); then compounds 4 and 3 (each within the scatter of the next).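

In this assay the change from dimethylamino to methylamino stays within the scatter on the chloro partner too (a 1.5-fold lower number from compound 3 to compound 4 (0.19 log units; within the scatter)), so it now reads alike on both cores: the same change on two cores in this assay, a 1.2-fold lower number (0.07 log units; within the scatter) from compound 1 to compound 2 and a 1.5-fold lower number (0.19 log units; within the scatter) from compound 3 to compound 4, 1.3-fold (0.12 log units) apart, within the scatter of two such steps.

The swap of chloro for fluoro keeps its size, beyond the scatter, when the nitrogen carries methylamino (a 4.9-fold higher number from compound 2 to compound 4 (0.69 log units; beyond the scatter)), so across these four compounds the two changes appear not to depend on each other: the same change on two cores in this assay, a 6.4-fold higher number (0.81 log units; beyond the scatter) from compound 1 to compound 3 and a 4.9-fold higher number (0.69 log units; beyond the scatter) from compound 2 to compound 4, 1.3-fold (0.12 log units) apart, within the scatter of two such steps.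

Still open, on these data alone, is whether that nitrogen would accept a free amino group or a longer chain such as ethyl, and what bromo would do in place of chloro.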